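Aryl swap at the core: from furan to fluoropyridine

This account rests on a few compounds, and the source may have more. Where it says the series, first, only, none or still open, it means among the compounds named here.

The series shares one core carrying a diarylmethyl group and a carboxymethyl group; the variable aromatic group sits on the ring carbon next to the ring nitrogen. Compound 1 `O=C(O)Cc1sc(C(c2ccc(F)cc2)c2ccc(F)cc2)nc1-c1cccc(F)c1` carries 3-fluorophenyl there and in an in vitro assay on HEK385-7 cells for displacement of a labelled ligand from prostaglandin D2 receptor 2 (Homo sapiens) (a higher number here means a weaker inhibitor, a lower number a stronger inhibitor), compound 1 gives 1.4 nM. Compound 2 `O=C(O)Cc1sc(C(c2ccc(F)cc2)c2ccc(F)cc2)nc1-c1ccco1` carries furan-2-yl; in this assay compound 2 gives 18 nM. Compound 3 `O=C(O)Cc1sc(C(c2ccc(F)cc2)c2ccc(F)cc2)nc1-c1ccoc1` carries furan-3-yl; in this assay compound 3 gives 14 nM, the second highest number of the three, with compound 2 nearest and compound 1 furthest away.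

Going by the values given here, the steps so far: a 13-fold higher number from compound 1 to compound 2 (1.11 log units; beyond the scatter) and a 10-fold higher number from compound 1 to compound 3 (1.00 log units; beyond the scatter), while a 1.3-fold lower number from compound 2 to compound 3 (0.11 log units; within the scatter).

Compound 4 `O=C(O)Cc1sc(C(c2ccc(F)cc2)c2ccc(F)cc2)nc1-c1ccnc(F)c1` differs from compound 3 by 2-fluoropyridin-4-yl in place of furan-3-yl on an aromatic carbon. The entering group is nearer in kind to the 3-fluorophenyl of compound 1 than to either furan. Among the compounds with values here, the relevant step is the one from compound 1 to compound 3, which was modest and beyond the scatter; the change is expected to reverse much of it, so a lower number for compound 4 is expected, estimated as a 3.5-fold lower number from compound 3 to compound 4 (0.54 log units; beyond the scatter). Compound 4 is estimated at 4 nM, with a range from 1.5 nM to 14 nM.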

Compound 4, half-maximal inhibitory concentration: 0.48 nM
Compound 4: the middle estimate sits 8.3-fold (0.92 log units) above what was measured; measured number outside the range, below it.
By their numbers in this assay, from the lowest: compound 4; then compound 1; then compounds 3 and 2 (each within the scatter of the next).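

Compound 4 is the strongest of the four in this assay. With a 2.9-fold lower number from compound 1 to compound 4 (0.46 log units; beyond the scatter), 2-fluoropyridin-4-yl does more than recover what the furans gave up, and this position can go beyond the number set by 3-fluorophenyl. Against the furans the change is much larger, with a 29-fold lower number from compound 3 to compound 4 (1.46 log units; beyond the scatter) and a 38-fold lower number from compound 2 to compound 4 (1.57 log units; beyond the scatter), whereas furan-2-yl and furan-3-yl lie within the scatter of each other, so among these four compounds the choice of aromatic group at this position matters far more than the point of attachment of the furan. Nothing at hand accounts for the gain of compound 4 over the other three.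

The compounds shown leave open how the gain divides between the ring nitrogen and the fluorine, which a plain pyridin-4-yl group, or a 2-chloropyridin-4-yl group, would help to separate. Also open, from the compounds shown here alone, is whether the fluorine of the entering group can be exchanged for a larger substituent, as in 2-methoxypyridin-4-yl or 2-aminopyridin-4-yl, with the number staying as low as in compound 4.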